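Working notes: from compound 2 to compound 3

The source may report more compounds than this note shows. Statements on the series, on what has been measured and on what is new or still open speak of the compounds shown alone.

- compound 1 `COc1ccc(/C=N/NC(=O)c2cccc(S(=O)(=O)N3CCOCC3)c2)c(O)c1` gives 1090 nM
- compound 2 `CCOc1cccc(/C=N/NC(=O)c2cccc(S(=O)(=O)N3CCOCC3)c2)c1O` gives 15400 nM

In a functional assay on EC9706 cells (Homo sapiens) for antiproliferative activity, read by MTT assay, with a stated time of 72 h (on this read-out lower numbers stand for stronger inhibition and higher numbers for weaker inhibition), compound 2 stands highest of the two measured compounds, at 15400 nM so far. Going by the values given here, the only measured step, a 14-fold higher number from compound 1 to compound 2 (1.15 log units; beyond the scatter), is large and beyond the scatter. In that step, 3-ethoxy-2-hydroxyphenyl takes the place of 2-hydroxy-4-methoxyphenyl on a carbon with a double bond to nitrogen.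

Compound 3 `O=C(N/N=C/c1cc(Cl)ccc1O)c1cccc(S(=O)(=O)N2CCOCC2)c1` has not yet been measured. It carries 5-chloro-2-hydroxyphenyl in place of 3-ethoxy-2-hydroxyphenyl at that same place (5-chloro-2-hydroxyphenyl in place of 3-ethoxy-2-hydroxyphenyl on a carbon with a double bond to nitrogen). Among the compounds with values here, the change removes the group that came with the higher number in a 14-fold higher number from compound 1 to compound 2 (1.15 log units; beyond the scatter), and that single step is the only guide. Within the data shown here, no measured compound carries chlorine, so the size of any change remains poorly defined, and a return all the way to the level of compound 1 cannot be assumed. The estimated step is a 4.4-fold lower number from compound 2 to compound 3 (0.64 log units; beyond the scatter), in the direction of stronger inhibition. For compound 3 the expected value is 3500 nM, with an estimated range from 700 nM to 16000 nM in this read-out.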

Compound 3, half-maximal inhibitory concentration: 2150 nM
For compound 3 the middle estimate is 1.6-fold (0.21 log units) above the measured one; the range from low to high includes it.
By their numbers in this assay, from the lowest: compounds 1 and 3 (each within the scatter of the next); then compound 2.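

In this assay, 5-chloro-2-hydroxyphenyl in place of 3-ethoxy-2-hydroxyphenyl gives a 7.2-fold lower number from compound 2 to compound 3 (0.86 log units; beyond the scatter), so the high number of compound 2 is not shared by every hydroxyphenyl group on this carbon with a double bond to nitrogen. The comparison with the other active compound gives a 2.0-fold higher number from compound 1 to compound 3 (0.30 log units; within the scatter), which means that a chlorine-bearing ring and a methoxy-bearing ring give numbers that cannot be told apart in this assay, and so far the ethoxy-bearing compound 2 alone stands apart from them. No available data bear on the reason for these differences.

The three compounds shown vary both the substituent and its location on the ring, so the ethoxy group cannot be separated from where it sits, and chlorine, methoxy and ethoxy are never compared at one matched location. As far as these compounds go, it also remains open whether this place tolerates a quite different substituent, such as an amine or a carboxylic acid, and whether the number stays near those of compound 1 and compound 3 when the ring hydroxy group is absent.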